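Trading a hydroxy for a methyl at the cytotoxicity ceiling

The compounds below may be only part of what the source reports. "The series", "measured", "known", "first", "only" and "open" are said of these compounds alone.

Measured in an ADME assay on L929 cells (Mus musculus) for cytotoxicity, read by resazurin assay, with a stated time of 72 h; a lower number here means a stronger inhibitor, a higher number a weaker inhibitor:
- compound 1, `O=C(/C=C/c1ccc2c(c1)B(O)OC2)c1ccc(Cl)c(Cl)c1`, gives > 10 ug/mL, a limit of the assay.
- compound 2, `O=C(O)c1ccc(C(=O)/C=C/c2ccc3c(c2)B(O)OC3)cc1`, gives > 10 ug/mL, a limit of the assay.
- compound 3, `O=C(/C=C/c1ccc2c(c1)B(O)OC2)c1ccc(O)cc1`, gives > 10 ug/mL, a limit of the assay.

All three measured compounds share one core and differ only in the group on the far aryl ring. None of them yields a number in this assay; each sits at the limit of > 10 ug/mL in this assay, at which 3 of the 3 values shown sit, so compound 3 cannot be ranked against compound 1 or compound 2 at all. Among the measured compounds shown here, the one single-point step among them, a step that the two limits leave unreadable from compound 2 to compound 3, is left unreadable by the two limits.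

Compound 4, `Cc1ccc(C(=O)/C=C/c2ccc3c(c2)B(O)OC3)cc1`, is the next member. It differs from compound 3 in this way: methyl in place of hydroxy on an aromatic carbon. For the measured compounds named here, no measured step bears directly on this change; the only step recorded, from carboxy to hydroxy, gave no readable size, and the closest guide is that every compound so far stops at the limit of > 10 ug/mL in this assay, at which 3 of the 3 values shown sit. The expectation for compound 4 in this assay is therefore no step beyond the scatter, a step that the limit leaves unreadable from compound 3 to compound 4, with compound 4 most probably ending as another limit. Compound 4 is estimated at 15 ug/mL, in the range 8 ug/mL to 40 ug/mL.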

Compound 4, half-maximal inhibitory concentration: > 10 ug/mL
Compound 4: no number, only a limit; the forecaster's own chance of this, stated with the estimate: 80%; the middle value is on the limit's open side.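

In this assay, among the compounds shown here, compound 4 gives > 10 ug/mL, which is a limit and not a number, so no step from compound 2 or compound 3 to compound 4 can be read. What the compounds shown leave open is how compound 1, compound 2, compound 3 and compound 4 rank against one another, since none of them yields a number: the limit of > 10 ug/mL in this assay, at which 4 of the 4 values shown sit.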